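This account rests on a few compounds, and the source may have more. Where it says the series, first, only, none or still open, it means among the compounds named here.

Measured so far in an assay on isolated protein for inhibition of protein deacetylase HDAC6 (Homo sapiens), read by fluorescence, with stated times of 10 min and 30 min, tested at 10 uM; on this read-out lower numbers stand for less inhibition and higher numbers for more inhibition at the one concentration tested (going by the name of the read-out):
- compound 1 `CCOc1cc(NC(=O)CCCCCNC(=O)CCCc2ccccc2)cc2c1OCC([N+](=O)[O-])=C2` gives 43%
- compound 2 `CCOc1cc(NC(=O)CCCCCCC(=O)Nc2cc(-c3ccccc3)ccc2N)cc2c1OCC([N+](=O)[O-])=C2` gives 29%

Compound 1 stands highest of the two numbers. Its nearest neighbour, compound 2, lies lower by a margin beyond the usual scatter of this assay, so the two read-outs can be told apart.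

Compound 3 `CCOc1cc(NC(=O)CCCCCC(=O)Nc2ccccc2N)cc2c1OCC([N+](=O)[O-])=C2` has not yet been measured in this assay. Relative to compound 1 the change is (2-aminophenyl)carbamoyl in place of ((3-phenylpropyl)carbonyl)amino on a saturated chain carbon, five bonds along the chain from a carbonyl carbon. Among the measured compounds shown here, no pair of measured compounds differing in a single place is available, so the size of this step cannot be read from a neighbouring case; only the two measured values give a bearing. In its end group compound 3 resembles compound 2 more closely than compound 1, and compound 2 sits below compound 1 in this assay. A step downward beyond the scatter is therefore expected, estimated as a number 18 percentage points lower from compound 1 to compound 3 (beyond the scatter). Compound 3 is expected to give about 25% in this assay, with a likely range from 8% to 45%; the measurement will show whether the read-out falls with the end group as anticipated.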

Compound 3, a percentage reported as inhibition, at one concentration (the size of the read-out at that concentration, not a potency): 57%
The estimate for compound 3 lay 32 percentage points below the measured number; measured number above the stated range.
By their numbers in this assay, from the lowest: compound 2; then compound 1; then compound 3.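

In this assay, (2-aminophenyl)carbamoyl in place of ((3-phenylpropyl)carbonyl)amino on a saturated chain carbon, five bonds along the chain from a carbonyl carbon, gives a number 14 percentage points higher from compound 1 to compound 3 (beyond the scatter). Among the compounds shown here, this is the first single-place step: the read-out responds to the end group at this position, and with the core of compound 1 unchanged, the (2-aminophenyl)carbamoyl end group gives the higher number of the pair. The entering group differs from the leaving group in its counts of heavy atoms and hydrogen-bond donors, but no measurement at hand ties either difference, or any other feature of the two groups, to the step.

Still open, from the compounds shown here alone, is whether the amine of the (2-aminophenyl)carbamoyl group carries the step or whether the whole end group is needed, which a plain phenylcarbamoyl or a hydroxamic acid at the same place would help to separate. Going by these compounds, a longer chain with the same end group would show how far the step depends on chain length, and since this read-out comes from one concentration, a potency for either compound also remains open.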